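Methylamino for Methoxy on a Benzofuran Nucleoside Core

The source may hold more compounds than are shown below. What is called first, only, known or untested is meant among the compounds shown, and "the series" means these compounds.

Compound 1 `COc1ncnc2c1c(-c1ccoc1)cn2[C@@H]1O[C@H](CO)[C@@H](O)[C@H]1O` and compound 2 `CNc1ncnc2c1c(-c1ccoc1)cn2[C@@H]1O[C@H](CO)[C@@H](O)[C@H]1O` share one core and differ by methylamino in place of methoxy on an aromatic carbon. In an ADME assay on BJ cells (Homo sapiens), read by MTT assay, with a stated time of 72 h (on this read-out higher numbers stand for weaker inhibition and lower numbers for stronger inhibition), compound 1 gives 28800 nM, while compound 2 gives 96300 nM, so the change made a 3.3-fold higher number from compound 1 to compound 2 (0.52 log units; beyond the scatter). Compound 3 `COc1ncnc2c1c(-c1cc3ccccc3o1)cn2[C@@H]1O[C@H](CO)[C@@H](O)[C@H]1O` rests on a second core, which differs from the core of compound 1 by 1-benzofuran-2-yl in place of furan-3-yl on an aromatic carbon; in this assay compound 3 gives 22400 nM, and the step is a 1.3-fold lower number from compound 1 to compound 3 (0.11 log units; within the scatter). Compound 4 `CNc1ncnc2c1c(-c1cc3ccccc3o1)cn2[C@@H]1O[C@H](CO)[C@@H](O)[C@H]1O` has not yet been measured in this assay. It differs from compound 3 by methylamino in place of methoxy on an aromatic carbon, the same change as that between compound 1 and compound 2, made at a place described in the same words. The step from compound 3 to compound 4 is expected to be a 3.3-fold higher number from compound 3 to compound 4 (0.52 log units; beyond the scatter), an expectation that rests on a 3.3-fold higher number from compound 1 to compound 2 (0.52 log units; beyond the scatter) seen once on the other core, so the support is a single earlier instance. Compound 4 is therefore estimated to give 74000 nM in this assay, with a likely range from 35000 nM to 160000 nM.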

Compound 4, half-maximal inhibitory concentration: 75600 nM
Estimate against measurement, compound 4: 1.0-fold (0.01 log units) below, within the range that was stated.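

In this assay, methylamino in place of methoxy on an aromatic carbon gave a 3.4-fold higher number from compound 3 to compound 4 (0.53 log units; beyond the scatter), and this step matches the one seen earlier on the other core: the same change on two cores in this assay, a 3.3-fold higher number (0.52 log units; beyond the scatter) from compound 1 to compound 2 and a 3.4-fold higher number (0.53 log units; beyond the scatter) from compound 3 to compound 4, 1.0-fold (0.00 log units) apart, within the scatter of two such steps. The exchange of furan-3-yl for 1-benzofuran-2-yl, now read with methylamino in place, gave a 1.3-fold lower number from compound 2 to compound 4 (0.11 log units; within the scatter), so it stays within the scatter with either group on that carbon: the same change on two cores in this assay, a 1.3-fold lower number (0.11 log units; within the scatter) from compound 1 to compound 3 and a 1.3-fold lower number (0.11 log units; within the scatter) from compound 2 to compound 4, 1.0-fold (0.00 log units) apart, within the scatter of two such steps. Across these four compounds, each change therefore carried over from one core to the other with its size kept, but this rests on a single pair of steps for each change in one assay, and it shows neither that the same would hold on further cores nor why the steps agree.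

The compounds shown leave open whether a longer chain such as ethylamino, a dimethylamino group or a plain amine on the same aromatic carbon would follow the methylamino step. They also leave open whether a phenyl or thiophene group in place of the furan-3-yl would leave the methylamino step unchanged.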